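A few compounds are considered here, and "the series" means these few. Any claim that something is new, unique, unknown or untested is made for them only; others in the source may bear on it.

Of the compounds shown here, two have been tested so far. Compound 1 `Cc1ccc([C@@H]2CN(C)[C@]3(C(=O)Nc4ccccc43)[C@]23Cc2ccccc2C3=O)cc1` and compound 2 `CN1C(=O)[C@@]2(c3ccccc31)N(C)C[C@@H](c1ccco1)[C@@]21Cc2ccccc2C1=O` share the same core and differ in the aryl group on the ring and in the substitution on the amide nitrogen. In a functional assay on the whole organism (strain Wister albino) for inhibition, with Rattus norvegicus as the target, read by paw edema, with stated times of 1 h and 4 h, at a dose of 50 mg/kg by the intraperitoneal route (a higher number here means more inhibition at the dose given (going by the name of the read-out), a lower number less inhibition), compound 1 gives 17.1%, and in this assay compound 2 gives 8.2%. On paper compound 1 carries the bigger of the two figures, but the gap to compound 2 lies within the usual scatter of this measurement, so the two compounds cannot be told apart on these numbers.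

Compound 3 `CN1C[C@@H](c2ccc(Cl)cc2)[C@@]2(Cc3ccccc3C2=O)[C@@]12C(=O)Nc1ccccc12` is the next compound to be tested. It differs from compound 1 in a single place: chloro in place of methyl on an aromatic carbon. For the measured compounds named here, no pair of measured compounds shows this same change, so there is nothing in the data to say how it acts. With only that to go on, the expected step in this assay from compound 1 to compound 3 is a number 0.1 percentage points lower from compound 1 to compound 3 (within the scatter), which is small and not beyond the scatter. Compound 3 is therefore estimated to give 17%, with a range from 5% to 30%.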

Compound 3, a percentage reported as inhibition, in the whole organism at one dose (the size of the read-out at that dose, not a potency): 15.6%
Estimate against measurement, compound 3: 1.4 percentage points above, and the stated range covers the measured number.
By their numbers in this assay, from the lowest: compounds 2, 3 and 1 (each within the scatter of the next).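

In this assay, for the compounds shown here, the change from 4-methylphenyl to 4-chlorophenyl is the first one-place comparison, and it amounts to a number 1.5 percentage points lower from compound 1 to compound 3 (within the scatter). At this aromatic carbon, para to a large group, methyl and chloro therefore cannot be told apart at the single dose tested, so this one exchange gives no sign that the choice between these two groups matters for the reduction of paw swelling in the rat. The result rests on one pair of compounds, and no other measurement is available to explain why the two groups read alike.

As far as these compounds go, one small group exchanged for another of the same heavy-atom count tests only a narrow change, so it remains open whether an amine, a carboxylic acid or a longer chain on the same aromatic carbon would move the number beyond the scatter. From the compounds shown here alone, it is also open whether chloro in place of methyl would read the same way on a version of the shared core that carries a methyl group on the amide nitrogen.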